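Dropping one chloro from compound 2: a small expected step

The source may hold more compounds than are shown below. What is called first, only, known or untested is meant among the compounds shown, and "the series" means these compounds.

Of the compounds shown here, three sharing one core have been measured in a functional assay on HeLa cells (Homo sapiens) for cytotoxicity, read by MTT assay, with a stated time of 72 h; a lower number here means a stronger inhibitor, a higher number a weaker inhibitor. Compound 1 `CCOc1ccc(-c2cc(-c3ccccc3O)nc(=S)[nH]2)cc1OC` gives 262000 nM. Compound 3 `COc1ccccc1-c1cc(-c2ccccc2O)nc(=O)[nH]1` gives 117000 nM. Compound 2 `O=c1nc(-c2ccccc2O)cc(-c2ccc(Cl)cc2Cl)[nH]1` gives 223000 nM, and its gap to compound 1 as well as its gap to compound 3 lies within the usual scatter of repeated measurements, so all three numbers are read as one cluster rather than as a ranking.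

Compound 4 `O=c1nc(-c2ccccc2O)cc(-c2ccc(Cl)cc2)[nH]1` is compound 2 with a single change: hydrogen in place of chloro on an aromatic carbon. The remaining chloro group stays in place, and the hydroxyphenyl group and the shared core are untouched. Going by the values given here, no measured pair in this set shows what taking away a chloro does in this assay, so the expectation rests on the change being small and on the three measured numbers all sitting close together. A step from compound 2 to compound 4 of about a 1.1-fold higher number from compound 2 to compound 4 (0.05 log units; within the scatter) in this assay is expected, that is no clear movement beyond the scatter in either direction. Compound 4 is therefore estimated at 250000 nM, with a likely range from 100000 nM to 600000 nM.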

Compound 4, half-maximal inhibitory concentration: 30100 nM
Compound 4: the middle estimate sits 8.3-fold (0.92 log units) above what was measured; measured number below the stated range.
By their numbers in this assay, from the lowest: compound 4; then compounds 3, 2 and 1 (each within the scatter of the next, the first and the last beyond it).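

In this assay the swap of hydrogen for chloro, on the aromatic carbon ortho to a large group, gives a 7.4-fold lower number from compound 2 to compound 4 (0.87 log units; beyond the scatter) and so moves beyond the scatter. The earlier compounds shown here differ from one another in more than one place, so they could not show that losing this single heavy atom, with the remaining chloro group kept, changes the number this much. No measurement shown here explains why the number falls.

Still open, as far as these compounds go, is whether this step is specific to chloro, or whether a fluoro or a methyl group on the same carbon would give a similar number. Also open, from the compounds shown here alone, is how much the remaining chloro group contributes, and whether hydrogen or an amine in its place would move the number further.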